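The source may hold more compounds than are shown below. What is called first, only, known or untested is meant among the compounds shown, and "the series" means these compounds.

Compound 1 `CNC(=O)/C=C1\CCc2ccc(Br)cc21` gives 0% in a functional assay on the whole organism with Mus musculus as the target, at a dose of 100 mg/kg by the intraperitoneal route; on this read-out higher numbers stand for more inhibition at the one dose given (going by the name of the read-out) and lower numbers for less inhibition.
Compound 2 `CNC(=O)/C=C1\CCc2ccc(Cl)cc21` gives 16% in this assay.
Compound 3 `O=C(/C=C1\CCc2ccc(F)cc21)N1CCCC1` gives 33% in this assay.

Compound 1 stands lowest of the three: compound 2 lies a number 16 percentage points higher from compound 1 to compound 2 (beyond the scatter), and compound 3 gives a higher number still. Compound 4 `O=C(/C=C1\CCc2ccc(Br)cc21)NC1CC1` differs from compound 1 by cyclopropyl in place of methyl on an amide-type nitrogen. Among the measured compounds shown here, no measured step touches the amide-type nitrogen; the one step measured is a swap of chloro for bromo on an aromatic carbon, and compound 3 differs from compound 1 in two places at once, so its higher value cannot be tied to either change alone. The expectation for compound 4 therefore rests on little, and a small rise at most is expected, a number 10 percentage points higher from compound 1 to compound 4 (within the scatter). Compound 4 is estimated at 10%, within a range from 0% to 30%.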

Compound 4, a percentage reported as inhibition, in the whole organism at one dose (the size of the read-out at that dose, not a potency): 33%
Compound 4: middle estimate off by 23 percentage points, on the low side; the measured number lies above the stated range.
By their numbers in this assay, from the lowest: compound 1; then compound 2; then compounds 3 and 4 (each within the scatter of the next).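

Among the compounds shown here, the amide-type nitrogen, which no earlier step touched, turns out to matter in this assay: cyclopropyl in place of methyl gives a number 33 percentage points higher from compound 1 to compound 4 (beyond the scatter), with the bromo group kept. So the bromo compound's lack of inhibition is not fixed by the bromo group alone, since a change at this nitrogen by itself raises the number. Nothing measured here explains why this change has such an effect.

As far as these compounds go, whether an ethyl or cyclobutyl group on this nitrogen would do the same remains open. So does whether cyclopropyl would give a similar rise with chloro in place of bromo.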